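This account rests on a few compounds, and the source may have more. Where it says the series, first, only, none or still open, it means among the compounds named here.

Of the compounds shown here, two have been measured in an assay on cells (strain Sprague-Dawley) for inhibition of Polyunsaturated fatty acid 5-lipoxygenase (Rattus norvegicus), with a stated time of 30 min; on this read-out higher numbers stand for weaker inhibition and lower numbers for stronger inhibition. Compound 1 `CC(=O)Oc1ccc(/C=C/C(=O)OCCSc2nc(-c3ccc(S(C)(=O)=O)cc3)n(-c3ccc(F)cc3)n2)cc1OC(C)=O` gives 1050 nM in this assay. Compound 2 `CC(=O)Oc1ccc(/C=C/C(=O)OCCSc2nc(-c3ccc(S(C)(=O)=O)cc3)n(-c3ccccc3)n2)cc1OC(C)=O` gives 1210 nM in this assay. For the measured compounds named here, the single step between them, a 1.2-fold higher number from compound 1 to compound 2 (0.06 log units; within the scatter), exchanges fluoro for hydrogen on an aromatic carbon and stays inside the scatter. Going by the values given here, compound 2 thus holds the highest of the two numbers so far, but its only neighbour is compound 1, and the two cannot be told apart.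

Compound 3 `CC(=O)Oc1ccc(/C=C/C(=O)OCCSc2nc(-c3ccc(S(C)(=O)=O)cc3)n(-c3ccc(C(F)(F)F)cc3)n2)cc1OC(C)=O` is not yet measured. It differs from compound 2 by trifluoromethyl in place of hydrogen on an aromatic carbon. Among the compounds with values here, the only measured step that bears on this place, a 1.2-fold higher number from compound 1 to compound 2 (0.06 log units; within the scatter), was small, so no sign of any direction is available; how trifluoromethyl behaves here cannot be read from two compounds, and the spread is widened accordingly. The expectation for compound 3 is therefore a step of a 1.0-fold lower number from compound 2 to compound 3 (0.00 log units; within the scatter), not beyond the scatter. The estimate for compound 3 in this assay is 1200 nM, between 450 nM and 3200 nM.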

Compound 3, half-maximal inhibitory concentration: 1060 nM
Compound 3: the middle estimate sits 1.1-fold (0.05 log units) above what was measured; low and high end bracket the measured number.
By their numbers in this assay, from the lowest: compounds 1, 3 and 2 (each within the scatter of the next).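

Trifluoromethyl, with its 4 heavy atoms, replaces the hydrogen or fluoro on the aromatic carbon para to a large group, and in this assay a 1.1-fold lower number from compound 2 to compound 3 (0.06 log units; within the scatter) and a 1.0-fold higher number from compound 1 to compound 3 (0.00 log units; within the scatter) both stay within the scatter. The earlier pair covered only the exchange of hydrogen and fluoro, so it could not show whether this position would accept anything bigger; a group of several heavy atoms now sits there with no readable change in either step. Hydrogen, fluoro and trifluoromethyl therefore cannot be told apart at this place, and no order among them can be drawn in this read-out, while nothing available on these compounds speaks to why the number stays put.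

Whether this position responds at all remains open: all three groups shown carry no hydrogen-bond donor or acceptor and no charge, and an amine, a carboxylic acid or a longer alkyl chain at the same carbon could still move the number beyond the scatter. The compounds shown also vary in this one place only, so what the rest of the shared core contributes to the inhibition stays unresolved.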